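Chloro for fluoro: one swap measured, one expected

The source may hold more compounds than are shown below. What is called first, only, known or untested is meant among the compounds shown, and "the series" means these compounds.

Values in an assay on tissue (HeLa cells) for inhibition of Indoleamine 2,3-dioxygenase 1 (Homo sapiens), read by spectrophotometry; on this read-out higher numbers stand for weaker inhibition and lower numbers for stronger inhibition:

- compound 1 `O/N=C(/Nc1ccc(F)c(F)c1)c1ccc2occc2c1`: 14000 nM
- compound 2 `O/N=C(/Nc1ccc(F)c(Cl)c1)c1ccc2occc2c1`: 1800 nM
- compound 3 `COCc1cc2cc(/C(=N\O)Nc3cccc(F)c3)ccc2o1`: 6100 nM

Going by the values given here, the one change already measured is chloro in place of fluoro on an aromatic carbon, which gave a 7.8-fold lower number from compound 1 to compound 2 (0.89 log units; beyond the scatter). The same kind of change, (chloro in place of fluoro on an aromatic carbon), leads from compound 3 to compound 4 `COCc1cc2cc(/C(=N\O)Nc3cccc(Cl)c3)ccc2o1`, which is not yet measured. The two places are not identical: in the first pair the exchanged group sits ortho to a fluoro group, whereas in compound 3 and compound 4 it does not, and the core carrying the ring also differs. The difference between the two cores is not broken down here.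

In this assay compound 3 stands between compound 1 and compound 2. Because compound 1 to compound 2 showed a 7.8-fold lower number from compound 1 to compound 2 (0.89 log units; beyond the scatter), a gain of similar direction is expected for compound 4, but with the change transferred to a different core and a different neighbourhood, a somewhat smaller step is estimated: a 4.1-fold lower number from compound 3 to compound 4 (0.61 log units; beyond the scatter). Compound 4 is therefore expected to give 1500 nM in this assay, with the likely range set at 500 nM to 4500 nM.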

Compound 4, half-maximal inhibitory concentration: 2200 nM
For compound 4 the middle estimate is 1.5-fold (0.17 log units) below the measured one; the range from low to high includes it.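

In this assay, chloro in place of fluoro keeps its direction on the second core, with a 2.8-fold lower number from compound 3 to compound 4 (0.44 log units; beyond the scatter). The direction carries over, but the size of the step does not, as the two steps differ: the same change on two cores in this assay, a 7.8-fold lower number (0.89 log units; beyond the scatter) from compound 1 to compound 2 and a 2.8-fold lower number (0.44 log units; beyond the scatter) from compound 3 to compound 4, 2.8-fold (0.45 log units) apart, beyond the scatter of two such steps. This does not show what sets the size, as compound 1 and compound 2 carry a further fluoro group that compound 3 and compound 4 lack, their cores also differ, and these two pairs cannot separate those differences or give a rule for a third core.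

Open, on these data alone, is whether a larger halogen such as bromo, or a methyl or trifluoromethyl group, would extend the same step from the 3-fluorophenyl and 3-chlorophenyl compounds. Also open, as far as these compounds go, is whether the size of the step would shift if the methoxymethyl group of compound 3 and compound 4 gave way to a longer chain, an amine or a carboxylic acid.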